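Chloro to bromo in a growth inhibition series

The compounds below may be only part of what the source reports. "The series", "measured", "known", "first", "only" and "open" are said of these compounds alone.

Measured so far in a functional assay on NCI-H460 cells (Homo sapiens) for inhibition; on this read-out lower numbers stand for stronger inhibition of growth and higher numbers for weaker inhibition of growth
compound 1 `Cc1cc(-c2nc3c(F)cccc3s2)ccc1N` gives 1000 nM
compound 2 `Nc1ccc(-c2nc3cc(F)ccc3s2)cc1` gives 870 nM
compound 3 `Nc1ccc(-c2nc3cc(F)ccc3s2)cc1Cl` gives 40 nM

Compound 3 holds the lowest of the three numbers, and its gaps to both others lie beyond the scatter. The next compound, compound 4 `Nc1ccc(-c2nc3cc(F)ccc3s2)cc1Br`, has not yet been measured. It carries bromo in place of chloro on an aromatic carbon, ortho to an amino group and meta to a large group (bromo in place of chloro on an aromatic carbon). For the measured compounds named here, one measured step bears on this change: a 22-fold lower number from compound 2 to compound 3 (1.34 log units; beyond the scatter) (chloro in place of hydrogen on an aromatic carbon), which is large. Going by the values given here, no measured pair exchanges chloro for bromo, however, and compound 1 differs from the others in more than one place. Here bromo replaces chloro rather than hydrogen, so a step of that size is not carried over, and no step beyond the scatter is expected in this assay. The estimated step is a 1.1-fold lower number from compound 3 to compound 4 (0.06 log units; within the scatter) and is expected to stay within the scatter. For compound 4 the estimated value is 35 nM with an expected range from 12 nM to 100 nM across repeat measurements.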

Compound 4, concentration for 50% growth inhibition: 110 nM
Estimate against measurement, compound 4: 3.1-fold (0.50 log units) below; the measured number lies above the stated range.
By their numbers in this assay, from the lowest: compound 3; then compound 4; then compounds 2 and 1 (each within the scatter of the next).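

In this assay, the gain at the carbon ortho to the amino group is not confined to chloro: bromo in place of hydrogen also gives a clear drop, with a 7.9-fold lower number from compound 2 to compound 4 (0.90 log units; beyond the scatter). The two halogens are nevertheless not interchangeable here, as exchanging chloro for bromo gives a 2.8-fold higher number from compound 3 to compound 4 (0.44 log units; beyond the scatter), so compound 3 keeps the lowest number and compound 4 takes an intermediate place, short of the earlier 22-fold lower number from compound 2 to compound 3 (1.34 log units; beyond the scatter). Nothing available accounts for this difference between chloro and bromo.

The compounds shown leave open whether fluoro, methyl, methoxy or trifluoromethyl at this carbon would match chloro, bromo or hydrogen. They also leave open whether the gain from chloro or bromo would survive if the amino group were replaced by an acetamide.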